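The source may hold more compounds than are shown below. What is called first, only, known or untested is meant among the compounds shown, and "the series" means these compounds.

Compound 1 `Cc1ccc2nc(N3CCCc4ccc(F)cc4C3)cc(NCCN)c2c1` opens the set. In an ADME assay on HEp-2 cells (Homo sapiens) for cytotoxicity, read by CCK-8 assay, with a stated time of 5 days (a lower number here means that less compound is tolerated, a higher number that more compound is tolerated), compound 1 reaches only > 3200 nM, which is a limit of the assay rather than a number, as the limit of > 3200 nM in this assay, at which 1 of the 3 values shown sits, records. Compound 2 `Cc1ccc2nc(N3CCCc4ccc(F)cc4C3)cc(NC(C)(C)CN)c2c1` gives 25000 nM in this assay. Compound 3 `Cc1ccc2nc(N3CCCc4ccc(F)cc4C3)cc(NCC(C)(C)N)c2c1` gives 23000 nM in this assay, the lowest of the two numbers, and the step of a 1.1-fold lower number from compound 2 to compound 3 (0.04 log units; within the scatter) lies within the scatter, so the two cannot be told apart. The steps a step that the limit leaves unreadable from compound 1 to compound 2 and a step that the limit leaves unreadable from compound 1 to compound 3 stay unreadable behind the limit. Compound 4 `Cc1ccc2nc(N3CCCc4ccc(F)cc4C3)cc(NC(=O)CN)c2c1` differs from compound 3 by (aminomethyl)carbonyl in place of 2-amino-2-methylpropyl on a nitrogen on an aromatic ring. Among the measured compounds shown here, none of the measured steps swaps a saturated chain for a carbonyl-bearing group, so they give no direction for this change; the one readable step was within the scatter. Compound 4 is therefore expected to sit close by, with an estimated 23000 nM and a range of 8000 nM to 60000 nM. The step of no change at the digits printed from compound 3 to compound 4 (within the scatter) is expected to remain within the usual scatter, though the range is kept wide.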

Compound 4, half-maximal cytotoxic concentration: > 100000 nM
Compound 4 gave a limit, no number (the forecaster's own chance of this, stated with the estimate: 20%); middle value at least 4.3-fold (0.63 log units) away from the limit.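

In this assay compound 4 records a limit and not a number: the limit of > 100000 nM in this assay, at which 1 of the 4 values shown sits.
With (aminomethyl)carbonyl on the nitrogen on an aromatic ring, the data show an at least 4.3-fold higher number from compound 3 to compound 4 (0.63 log units; beyond the scatter) in place of 2-amino-2-methylpropyl and an at least 4.0-fold higher number from compound 2 to compound 4 (0.60 log units; beyond the scatter) in place of 1-(aminomethyl)-1-methylethyl, so this change moves the number beyond the scatter, whereas the swap between those two saturated chains did not. The steps from compound 1 to the other compounds cannot be read.

From the compounds shown here alone, how far compound 4 lies beyond its limit remains open. Going by these compounds, it is also open whether the higher number stays with a longer chain behind the carbonyl, such as 3-aminopropanoyl, or with a carboxylic acid in place of the terminal amine.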